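Changing the sulfonyl aryl group: from compound 3 to compound 4

The source may report more compounds than this note shows. Statements on the series, on what has been measured and on what is new or still open speak of the compounds shown alone.

Measured compounds in an assay on cells for inhibition of HSP60/HSP10 (Homo sapiens), with a stated time of 60 min; on this read-out higher numbers stand for weaker inhibition and lower numbers for stronger inhibition:
Compound 1, `Cc1ccccc1S(=O)(=O)Nc1ccc2oc(-c3ccccc3)nc2c1`, gives only a limit of the assay, > 100000 nM.
Compound 2, `O=S(=O)(Nc1ccc2oc(-c3ccccc3)nc2c1)c1cccc(O)c1`, gives 76000 nM.
Compound 3, `O=S(=O)(Nc1ccc2oc(-c3ccccc3)nc2c1)c1ccc(Cl)cc1`, gives only a limit of the assay, > 100000 nM.

Compound 3 stands at the limit of > 100000 nM in this assay, at which 2 of the 3 values shown sit. Compound 4, `COc1ccccc1S(=O)(=O)Nc1ccc2oc(-c3ccccc3)nc2c1`, differs from it by 2-methoxyphenyl in place of 4-chlorophenyl on a sulfonyl sulfur. For the measured compounds named here, two measured steps touch this position: an at least 1.3-fold higher number from compound 2 to compound 3 (0.11 log units; that floor lies within the scatter) and a step that the two limits leave unreadable from compound 1 to compound 3. Neither reads as a change beyond the scatter, and compound 1, which also carries a 2-substituted aryl group, gives only a limit. The step that the limit leaves unreadable from compound 3 to compound 4 is therefore expected to be small, most likely leaving compound 4 at the limit as well. Compound 4 is expected to give about 110000 nM, within a range from 50000 nM to 300000 nM.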

Compound 4, half-maximal inhibitory concentration: > 100000 nM
Compound 4 was reported as a limit (the forecaster's own chance of this, stated with the estimate: 70%); the middle value does not contradict the limit.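

For the compounds shown here, compound 4 adds a third sulfonyl aryl group that gives only a limit in this assay: the limit of > 100000 nM in this assay, at which 3 of the 4 values shown sit. The one readable step is an at least 1.3-fold higher number from compound 2 to compound 4 (0.11 log units; that floor lies within the scatter), so 2-methoxyphenyl and 3-hydroxyphenyl are not separated beyond the scatter. The steps from compound 1 and from compound 3 to compound 4 have limits at both ends and cannot be read.

Still open, from the compounds shown here alone, is whether a phenyl group carrying an amine or a carboxylic acid on the sulfonyl sulfur would give a value clearly below the limit.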